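A few compounds are considered here, and "the series" means these few. Any claim that something is new, unique, unknown or untested is made for them only; others in the source may bear on it.

Measured compounds:
- compound 1, `CC1N=C(S)N(Nc2cccc(Cl)c2)C1C`: 259000 nM
- compound 2, `Cc1nc(S)n(Nc2cccc(Cl)c2)c1-c1cccc(Cl)c1`: 31000 nM
- compound 3, `CC1N=C(S)N(Nc2ccccc2)C1C`: 181000 nM

The series was run in a functional assay on MT4 cells (Homo sapiens) for cytotoxicity; on this read-out lower numbers stand for higher toxicity in this test and higher numbers for lower toxicity in this test. Compound 1 `CC1N=C(S)N(Nc2cccc(Cl)c2)C1C` gives 259000 nM in this assay, compound 3 `CC1N=C(S)N(Nc2ccccc2)C1C` gives 181000 nM, and compound 2 `Cc1nc(S)n(Nc2cccc(Cl)c2)c1-c1cccc(Cl)c1` gives 31000 nM. Compound 2 stands at the lowest number of the three; its gaps to compound 3 and to compound 1 are both beyond the scatter, so it is the most toxic compound measured here. The difference between the core of compound 2 and the core of compound 1 is not broken down here.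

Compound 1 and compound 3 differ in one place, (hydrogen in place of chloro on an aromatic carbon). This change gave a 1.4-fold lower number from compound 1 to compound 3 (0.16 log units; within the scatter).

Compound 4 `Cc1nc(S)n(Nc2cccc(Cl)c2)c1-c1ccccc1` is not yet measured. It differs from compound 2 by hydrogen in place of chloro on an aromatic carbon. Around the place, the two descriptions are not identical: in compound 1 the chloro sits meta to a group of 9 heavy atoms, in compound 2 meta to a large group, so the change is of the same kind rather than the same.

Because the same kind of change gave a 1.4-fold lower number from compound 1 to compound 3 (0.16 log units; within the scatter), the step from compound 2 to compound 4 is expected to be of a similar size, a 1.2-fold lower number from compound 2 to compound 4 (0.09 log units; within the scatter), and this rests on a single pair only. Compound 4 is therefore estimated at 25000 nM, with a range from 12000 nM to 55000 nM.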

Compound 4, half-maximal cytotoxic concentration: 66700 nM
Beside the measured number, compound 4's estimate is 2.7-fold (0.43 log units) below it, outside the stated range (above it).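

In this assay, the replacement of chloro by hydrogen, read on this core as 3-chlorophenyl to phenyl, gave a 2.2-fold higher number from compound 2 to compound 4 (0.33 log units; beyond the scatter), a modest step towards lower toxicity in this test. The change therefore does not carry over from one core to the other with a fixed size, and the two steps stand apart by more than their scatter: the same change on two cores in this assay, a 1.4-fold lower number (0.16 log units; within the scatter) from compound 1 to compound 3 and a 2.2-fold higher number (0.33 log units; beyond the scatter) from compound 2 to compound 4, 3.1-fold (0.49 log units) apart, beyond the scatter of two such steps Since the earlier step lies within the scatter, this shows a dependence on context rather than a true reversal of direction, and with a single pair on each core it does not show whether the core itself, the particular aromatic ring that loses its chloro, or some other feature accounts for the gap.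

The compounds shown leave open whether the removal of the chloro that remains in compound 4 would follow either step, and so whether the two chloro groups on the core of compound 2 count alike in this test. They also leave open how other groups in the same place, such as a methoxy group, an amine or a carboxylic acid, would behave on each of the two cores.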